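The source may hold more compounds than are shown below. What is called first, only, known or untested is meant among the compounds shown, and "the series" means these compounds.

Measured so far:
compound 1, `C=C[C@@H]1OC(c2ccc(-c3ccccc3)cc2)=N[C@H]1Sc1ccccc1`, with > 100000 nM;
compound 2, `C=C[C@@H]1OC(c2ccc(Br)cc2)=N[C@H]1SC(C)=O`, with 88000 nM.

In an assay on isolated protein for inhibition of matrix metalloproteinase-9 (Homo sapiens) (a lower number here means a stronger inhibitor, a higher number a weaker inhibitor), compound 1 reaches only the assay limit, (the limit of > 100000 nM in this assay, at which 1 of the 2 values shown sits), so no number is known for it. Among the compounds with values here, compound 2 is therefore the only compound with a number in this assay, and that number is a weak one. Compound 3, `C=C[C@@H]1OC(c2ccc(-c3ccccc3)cc2)=N[C@H]1SC(C)=O`, is still to be measured. It arises from compound 2 by one change: phenyl in place of bromo on an aromatic carbon. Within the data shown here, no measured pair tells how large a step this change brings in this assay, and compound 1, which also carries the phenyl but differs from compound 3 in a second place as well, sits at the limit. The expected step from compound 2 to compound 3 is a 1.1-fold higher number from compound 2 to compound 3 (0.06 log units; within the scatter), which is little beyond the scatter and more likely toward weaker. Compound 3 is estimated at 100000 nM, within 30000 nM to 300000 nM.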

Compound 3, inhibition constant: 81000 nM
For compound 3 the middle estimate is 1.2-fold (0.09 log units) above the measured one; measured number inside the range.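

In this assay phenyl in place of bromo on the aromatic carbon gives a 1.1-fold lower number from compound 2 to compound 3 (0.04 log units; within the scatter) and so puts compound 2 and compound 3 level, both weak inhibitors, even though the entering group brings a whole six-membered aromatic ring where a single atom stood. At the sulfur, acetyl in place of phenyl gives an at least 1.2-fold lower number from compound 1 to compound 3 (0.09 log units; that floor lies within the scatter) and so shows no clear effect of that swap. That step is only a floor, since compound 1 stands at a limit: the limit of > 100000 nM in this assay, at which 1 of the 3 values shown sits.

Going by these compounds, what an amine or a carboxylic acid would do on the same aromatic carbon stays open, as the two groups compared there carry no hydrogen-bond donors or acceptors and no charge. On these data alone, whether a longer chain on the sulfur in place of acetyl would give a clearly lower number also stays open.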